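A few compounds are considered here, and "the series" means these few. Any claim that something is new, unique, unknown or untested is made for them only; others in the source may bear on it.

Measured compounds:

Compound 1, `O=C(Nc1ccc(Oc2ccnc3[nH]ccc23)cc1)c1cc(-c2ccc(Cl)cc2)ccn1`: 25100 nM
Compound 2, `Cc1cccc(-c2ccnc(C(=O)Nc3ccc(Oc4ccnc5[nH]ccc45)cc3)c2)c1`: 5470 nM
Compound 3, `Cc1cccc(-c2ccnc(C(=O)Nc3ccc(Oc4ccnc5[nH]ccc45)c(F)c3)c2)c1`: 860 nM

These numbers come from a functional assay on PC-3 cells (Homo sapiens) for cytotoxicity, read by MTT assay, with a stated time of 72 h; a higher number here means a weaker inhibitor, a lower number a stronger inhibitor. Among the three, compound 3 gives the lowest number, and both gaps to it, a 6.4-fold lower number from compound 2 to compound 3 (0.80 log units; beyond the scatter) and the larger one from compound 1, lie beyond the scatter.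

Compound 4, `O=C(Nc1ccc(Oc2ccnc3[nH]ccc23)c(F)c1)c1cc(-c2ccc(C(F)(F)F)cc2)ccn1`, has not yet been measured. It differs from compound 3 in one place: 4-(trifluoromethyl)phenyl in place of 3-methylphenyl on an aromatic carbon. Of the measured steps, only a 4.6-fold lower number from compound 1 to compound 2 (0.66 log units; beyond the scatter) changes this same group, and there the number fell. The step of a 6.4-fold lower number from compound 2 to compound 3 (0.80 log units; beyond the scatter) concerns the fluoro and does not bear on this change. Since 4-(trifluoromethyl)phenyl is closer in kind to the 4-chlorophenyl of compound 1 than to 3-methylphenyl, the number is expected to rise again, so a step of about a 3.5-fold higher number from compound 3 to compound 4 (0.54 log units; beyond the scatter) is estimated. Compound 4 is therefore expected to give about 3000 nM, within a range of 1000 nM to 10000 nM.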

Compound 4, half-maximal inhibitory concentration: 4350 nM
The estimate for compound 4 lay 1.5-fold (0.16 log units) below the measured number; measured number inside the range.
By their numbers in this assay, from the lowest: compound 3; then compounds 4 and 2 (each within the scatter of the next); then compound 1.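

The step of a 5.1-fold higher number from compound 3 to compound 4 (0.70 log units; beyond the scatter) shows that the 3-methylphenyl group gives the lower number at this position, opposite the ring nitrogen, in a compound that carries the fluoro as well as in one that does not, since compound 2 had already given the lower number against compound 1 without it. The replaced group this time is 4-(trifluoromethyl)phenyl rather than 4-chlorophenyl, so the same result now holds against two different groups at this position. No measured evidence here explains why the number changes at this position.

Both steps change the substituent and where it sits on the phenyl ring together, so 4-methylphenyl would be needed to tell those two apart. As far as these compounds go, how an amine or a carboxylic acid on that phenyl ring would behave remains open.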